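Dienone series: dimethylamino for fluoro on the aryl ring

A few compounds are considered here, and "the series" means these few. Any claim that something is new, unique, unknown or untested is made for them only; others in the source may bear on it.

Among the compounds with values here, compound 1 `O=C1C=CCC/C1=C\C=C\c1ccc(F)cc1` is the weaker of the two measured members in a functional assay on Bel7402/5-FU cells (Homo sapiens) for cytotoxicity, read by MTT assay, with a stated time of 72 h (a higher number here means a weaker inhibitor, a lower number a stronger inhibitor), giving 1900 nM. Compound 2 `COc1cc(/C=C/C=C2\CCC=CC2=O)ccc1O` gives 800 nM in this assay, a lower number than compound 1 by a margin that lies beyond the usual scatter. The unmeasured compound 3 `CN(C)c1ccc(/C=C/C=C2\CCC=CC2=O)cc1` keeps the core of compound 1 and differs in one place: dimethylamino in place of fluoro on an aromatic carbon. No step between measured compounds covers this exchange, so the expectation rests only on the two numbers shown and on the change itself. The expected step of a 1.6-fold lower number from compound 1 to compound 3 (0.20 log units; within the scatter) is a modest move toward a lower number, close to the edge of the scatter. Compound 3 is therefore estimated at 1200 nM in this assay, with a range from 400 nM to 3500 nM.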

Compound 3, half-maximal inhibitory concentration: 1000 nM
Estimate against measurement, compound 3: 1.2-fold (0.08 log units) above; low and high end bracket the measured number.
By their numbers in this assay, from the lowest: compounds 2, 3 and 1 (each within the scatter of the next, the first and the last beyond it).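

On the aromatic carbon para to a large group, dimethylamino in place of fluoro gives, in this assay, a 1.9-fold lower number from compound 1 to compound 3 (0.28 log units; within the scatter), so compound 1 and compound 3 cannot be told apart on this read-out. This position therefore accepts a group of 3 heavy atoms, including a hydrogen-bond acceptor, in place of a single fluorine without a change that stands clear of the scatter. No measurement bearing on this result accompanies these compounds.

From the compounds shown here alone, whether a primary amino group, a morpholine ring or a carboxylic acid at this carbon would also stay level with compound 1 in this assay remains open. Also open, going by these compounds, is how dimethylamino would behave on another carbon of the aromatic ring.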